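Lengthening the linker in a dichlorophenoxy piperidine ester series

A few compounds are considered here, and "the series" means these few. Any claim that something is new, unique, unknown or untested is made for them only; others in the source may bear on it.

Of the compounds shown here, three sharing a common core have been tested in an in vitro functional assay on HEK ts201 cells for antagonist activity at Neuronal acetylcholine receptor; alpha3/beta4 (Homo sapiens), read by fluorescence and calcium flux; a higher number here means a weaker inhibitor, a lower number a stronger inhibitor. Compound 1 `COc1ccc(OCCCCCN2CCCC(COC(=O)c3ccccc3N3C(=O)CC(C)C3=O)C2)cc1OC` gives 2000000 nM. Compound 2 `CC1CC(=O)N(c2ccccc2C(=O)OCC2CCCN(CCCCCc3ccccc3)C2)C1=O` gives 4170 nM. Compound 3 `CC1CC(=O)N(c2ccccc2C(=O)OCC2CCCN(CCCCOc3ccc(Cl)c(Cl)c3)C2)C1=O` gives 74100 nM, which places it second highest of the three: the step from compound 2 is an 18-fold higher number from compound 2 to compound 3 (1.25 log units; beyond the scatter), while the step from compound 1 is a 27-fold lower number from compound 1 to compound 3 (1.43 log units; beyond the scatter). The further change a 480-fold lower number from compound 1 to compound 2 (2.68 log units; beyond the scatter) shows how strongly this part of the molecule governs the read-out.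

Compound 4 `CC1CC(=O)N(c2ccccc2C(=O)OCC2CCCN(CCCCCOc3ccc(Cl)c(Cl)c3)C2)C1=O` has not yet been measured. It differs from compound 3 in one place: (3,4-dichlorophenoxy)methyl in place of 3,4-dichlorophenoxy on a saturated chain carbon, four bonds along the chain from an amine nitrogen in a ring. In plain terms, the chain between the ring nitrogen and the aryl oxygen grows by one carbon.

Within the data shown here, no measured pair isolates this exact change. The nearest comparison is a 27-fold lower number from compound 1 to compound 3 (1.43 log units; beyond the scatter), where a longer chain went together with the weaker number, but the aryl substituents changed at the same time, so it only loosely bears on compound 4. Given that, the step of a 1.6-fold higher number from compound 3 to compound 4 (0.21 log units; within the scatter) is expected to be modest and its direction uncertain. Compound 4 is therefore estimated at 120000 nM in this assay, with a plausible range from 25000 nM to 600000 nM.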

Compound 4, half-maximal inhibitory concentration: 9120 nM
Beside the measured number, compound 4's estimate is 13-fold (1.12 log units) above it; measured number below the stated range.
By their numbers in this assay, from the lowest: compound 2; then compound 4; then compound 3; then compound 1.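

Among these compounds, compound 3 and compound 4 differ only by the added carbon in the chain, and in this assay that change alone gives an 8.1-fold lower number from compound 3 to compound 4 (0.91 log units; beyond the scatter) and so gives a stronger inhibitor, something the earlier comparisons could not show, since the groups on the aromatic ring changed along with the chain length. With the chain length held fixed, the pair of compounds 1 and 4 now isolates the groups on the aromatic ring: 3,4-dichlorophenyl in place of 3,4-dimethoxyphenyl gives a 220-fold lower number from compound 1 to compound 4 (2.34 log units; beyond the scatter) and is by far the largest of the new steps. Replacing phenyl with 3,4-dichlorophenoxy at the same chain length costs much less, with a 2.2-fold higher number from compound 2 to compound 4 (0.34 log units; beyond the scatter) as a modest step that still lies beyond the scatter, so the phenyl compound keeps the lowest number of the four.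

Going by these compounds, whether a still longer chain would lower the number further, or whether a carboxylic acid on the aromatic ring would be tolerated, stays open. No measurement shown here explains why these steps have the sizes they do.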